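Methyl to Methoxy in a Series of Aryl Amides

The compounds below may be only part of what the source reports. "The series", "measured", "known", "first", "only" and "open" are said of these compounds alone.

Compound 1 `Cc1ccc(-c2ccnc(C(=O)Nc3ccc(Oc4ccnc5[nH]ccc45)cc3)c2)cc1` and compound 2 `COc1ccc(-c2ccnc(C(=O)Nc3ccc(Oc4ccnc5[nH]ccc45)cc3)c2)cc1` share one core and differ in a single group. In a functional assay on PC-3 cells (Homo sapiens) for cytotoxicity, read by MTT assay, with a stated time of 72 h (a lower number here means a stronger inhibitor, a higher number a weaker inhibitor), compound 1 reaches only the limit of the assay, > 10000 nM, which is a limit and not a number (the limit of > 10000 nM in this assay, at which 1 of the 3 values shown sits). In this assay compound 2 gives 9620 nM. The change between them, (methoxy in place of methyl on an aromatic carbon), produced an at least 1.0-fold lower number from compound 1 to compound 2 (0.01 log units; that floor lies within the scatter). Compound 3 `Cc1ccc(-c2ccc(C(=O)Nc3ccc(Oc4ccnc5[nH]ccc45)c(F)c3)nc2)cc1` is built on another core; the difference between the two cores is not broken down here. In this assay compound 3 gives 2640 nM, the lowest of the two numbers. Compound 4 `COc1ccc(-c2ccc(C(=O)Nc3ccc(Oc4ccnc5[nH]ccc45)c(F)c3)nc2)cc1` has not yet been measured; it differs from compound 3 by methoxy in place of methyl on an aromatic carbon, the same change as between compound 1 and compound 2, at a place described in the same words. Because that earlier step was an at least 1.0-fold lower number from compound 1 to compound 2 (0.01 log units; that floor lies within the scatter), the step to compound 4 is expected to be of similar size, a 1.1-fold lower number from compound 3 to compound 4 (0.04 log units; within the scatter). Compound 4 is therefore expected to give about 2400 nM in this assay, with a likely range from 1000 nM to 5800 nM.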

Compound 4, half-maximal inhibitory concentration: 650 nM
Compound 4: the middle estimate sits 3.7-fold (0.57 log units) above what was measured, and the stated range ends above it.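

On the core of compound 3, replacing 4-methylphenyl with 4-methoxyphenyl gives a 4.1-fold lower number from compound 3 to compound 4 (0.61 log units; beyond the scatter) in this assay, so on this core the change clearly lowers the number. On the core of compound 1, the size of the same change cannot be pinned down: compound 1 gives > 10000 nM, which is a limit of the assay and not a number. The series therefore shows that the change can lower the number on one core, but it does not show whether the change carries over to the other core with the same size, or with a different one: the same change on two cores in this assay, an at least 1.0-fold lower number (0.01 log units; that floor lies within the scatter) from compound 1 to compound 2 and a 4.1-fold lower number (0.61 log units; beyond the scatter) from compound 3 to compound 4; the limit leaves it open whether they differ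

From the compounds shown here alone, only methyl and methoxy appear at this place on the aromatic ring, so it remains open how a chlorine, an amine or a longer chain such as ethoxy would behave there. Two pairs of compounds also cannot show whether the change would lower the number on a third core.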